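Moving a Fluorine Around the Phenyl Ring

The source may hold more compounds than are shown below. What is called first, only, known or untested is meant among the compounds shown, and "the series" means these compounds.

Compound 1, `CNCc1cc(-c2ccccc2)n(S(=O)(=O)c2ccc(C)cc2)c1`, is measured in a physicochemical assay for lipophilicity, read by HPLC, at pH 7.4 (on this read-out higher numbers stand for higher lipophilicity and lower numbers for lower lipophilicity), where compound 1 gives 1.83. Compound 2, `CNCc1cc(-c2cccc(F)c2)n(S(=O)(=O)c2ccc(C)cc2)c1`, carries a fluorine on one of its phenyl rings; in this assay compound 2 gives 1.98. Among the measured compounds shown here, the only change between them, fluoro in place of hydrogen on an aromatic carbon, gives a number 0.15 log units higher from compound 1 to compound 2 (within the scatter). Compound 2 and compound 1 therefore give numbers that lie within the scatter of each other, and no order can be read between them.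

Compound 3, `CNCc1cc(-c2ccc(F)cc2)n(S(=O)(=O)c2ccc(C)cc2)c1`, keeps every atom of compound 2 but joins them differently: 4-fluorophenyl in place of 3-fluorophenyl on an aromatic carbon. For the measured compounds named here, no measured step moves a fluorine from one ring carbon to another, so the one step seen, from compound 1 to compound 2, bears only indirectly: adding the fluorine itself stayed within the scatter. Shifting that same fluorine is expected to give no step beyond the scatter, so for compound 3 the expected change is a number 0.02 log units higher from compound 2 to compound 3 (within the scatter). Compound 3 is estimated at 2 in this assay, with a range from 1.75 to 2.3.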

Compound 3, distribution coefficient: 2.05
The estimate for compound 3 lay 0.05 log units below the measured number; measured number inside the range.
By their numbers in this assay, from the lowest: compounds 1, 2 and 3 (each within the scatter of the next).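

Shifting the fluorine, with 4-fluorophenyl in place of 3-fluorophenyl, gives a number 0.07 log units higher from compound 2 to compound 3 (within the scatter) in this assay. Among the compounds shown here, this is the first direct reading of a move around this phenyl ring, and it shows that the two placements cannot be told apart by this measurement. Fluoro in place of hydrogen at the 4-fluorophenyl placement gives a number 0.22 log units higher from compound 1 to compound 3 (within the scatter), so the added fluorine stays within the scatter at both placements, and nothing measured here offers an explanation for these small differences.

Still open, on these data alone, is whether a different group on this phenyl ring, such as trifluoromethyl, methoxy or a carboxylic acid, would give a step beyond the scatter rather than one as small as those seen with fluorine. The compounds shown also leave open whether the fluorine shift would give an equally small step if a longer chain stood in place of the (methylamino)methyl group.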